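A few compounds are considered here, and "the series" means these few. Any claim that something is new, unique, unknown or untested is made for them only; others in the source may bear on it.

Compound 1 `COc1ccc(C2=NN(C3=NC(=O)/C(=C4\C(=O)Nc5ccc(Br)cc54)S3)C(c3ccc(Cl)cc3)C2)cc1` and compound 2 `COc1ccc(C2=NN(C3=NC(=O)/C(=C4\C(=O)Nc5ccc(Cl)cc54)S3)C(c3ccc(Cl)cc3)C2)cc1` share one core and differ only in a single halogen. In a functional assay on cells (Leukemia cell, Homo sapiens) for cytotoxicity, read by sulforhodamine B assay, with a stated time of 48 h (a higher number here means a weaker inhibitor of growth, a lower number a stronger inhibitor of growth), compound 1 gives 190 nM, and compound 2 gives 270 nM. The change, (chloro in place of bromo on an aromatic carbon), produces a 1.4-fold higher number from compound 1 to compound 2 (0.15 log units; within the scatter). Compound 3 `CN(C)c1ccc(C2CC(c3ccccc3)=NN2C2=NC(=O)/C(=C3\C(=O)Nc4ccc(Br)cc43)S2)cc1` carries a different core, and how that core differs from the core of compound 1 is not broken down here; in this assay compound 3 gives 310 nM. Compound 4 `CN(C)c1ccc(C2CC(c3ccccc3)=NN2C2=NC(=O)/C(=C3\C(=O)Nc4ccc(Cl)cc43)S2)cc1` has not been measured yet. It differs from compound 3 by chloro in place of bromo on an aromatic carbon, the same change that separates compound 1 and compound 2. The expected step is a 1.3-fold higher number from compound 3 to compound 4 (0.11 log units; within the scatter) because the matching pair shows a 1.4-fold higher number from compound 1 to compound 2 (0.15 log units; within the scatter). Compound 4 is therefore estimated in this assay at 400 nM, with a range from 200 nM to 800 nM.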

Compound 4, concentration for 50% growth inhibition: 340 nM
Estimate against measurement, compound 4: 1.2-fold (0.07 log units) above; the range from low to high includes it.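

In this assay, chloro in place of bromo gives a 1.1-fold higher number from compound 3 to compound 4 (0.04 log units; within the scatter), and this step can be set beside the one on the other core: the same change on two cores in this assay, a 1.4-fold higher number (0.15 log units; within the scatter) from compound 1 to compound 2 and a 1.1-fold higher number (0.04 log units; within the scatter) from compound 3 to compound 4, 1.3-fold (0.11 log units) apart, within the scatter of two such steps. The two cores therefore give no sign that the swap behaves differently on one than on the other, and on both the step stays within the scatter. This does not show that the swap has a real effect of any size, and two pairs say nothing about how it would behave on a third core.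

As far as these compounds go, both pairs hold only bromo and chloro at this place, so what a fluoro, a methoxy or an amine there would give stays open. From the compounds shown here alone, a larger step from any of these groups, and whether it would carry between the two cores, also remains unknown.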